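Chloropyridinone Replacing Methoxypyridine in a Sulfone Series

A few compounds are considered here, and "the series" means these few. Any claim that something is new, unique, unknown or untested is made for them only; others in the source may bear on it.

Compound 1, `CCCCc1nc(=O)c(S(=O)(=O)c2ccc(-n3ccccc3=O)cc2)c(O)n1-c1c(OC)cccc1OC`, gives 87%.
Compound 2, `CCCCc1[nH]c(=O)c(S(=O)(=O)c2ccc(-c3cccnc3OC)cc2)c(O)c1-c1c(OC)cccc1OC`, gives 72%.

In an ADME assay on microsomes from liver (Homo sapiens) for metabolic stability, using NADPH, with a stated time of 10 min (a lower number here means that less of the compound is left, a higher number that more of the compound is left), compound 2 stands lowest of the two numbers shown; its nearest neighbour is compound 1, which is higher by a margin beyond the usual scatter. Compound 3, `CCCCc1[nH]c(=O)c(S(=O)(=O)c2ccc(-n3cc(Cl)ccc3=O)cc2)c(O)c1-c1c(OC)cccc1OC`, has not been measured. It differs from compound 2 by a group of 8 heavy atoms (5 carbon, 1 nitrogen, 1 oxygen, 1 chlorine; one six-membered aromatic ring with 1 hetero atom) in place of a group of 8 heavy atoms (6 carbon, 1 nitrogen, 1 oxygen; one six-membered aromatic ring with 1 hetero atom), on an aromatic carbon. Within the data shown here, no directly comparable pair is available, so the step from compound 2 to compound 3 cannot be read from measured data. A modest rise is expected, a number 6 percentage points higher from compound 2 to compound 3 (within the scatter), though it may stay within the scatter. Compound 3 is therefore estimated at 78%, with a range from 60% to 92%.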

Compound 3, percent of the compound remaining: 97%
Compound 3: the middle estimate sits 19 percentage points below what was measured; measured number outside the range, above it.
By their numbers in this assay, from the lowest: compound 2; then compounds 1 and 3 (each within the scatter of the next).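

In this assay, replacing the 2-methoxypyridin-3-yl group on an aromatic carbon para to a large group gives a number 25 percentage points higher from compound 2 to compound 3 (beyond the scatter), with the rest of the molecule unchanged. Among these compounds, this is the first measured change at this position, and it shows that the group held there can by itself move the percent remaining beyond the scatter. No measurement at hand speaks to why the number moved. The compounds shown leave open whether the chlorine or the ring carrying it accounts for the step. From the compounds shown here alone, how a fluorine, a methyl or an amine in the chlorine's place would fare also remains open.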